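From Methoxymethyl to Isopropoxymethyl in a Cell Assay

The compounds below may be only part of what the source reports. "The series", "measured", "known", "first", "only" and "open" are said of these compounds alone.

In a functional assay on A-431 cells (Homo sapiens) for inhibition, with a stated time of 72 h (a higher number here means a weaker inhibitor, a lower number a stronger inhibitor), compound 1 `CC1CCN(Cc2cc(Cl)c3cccnc3c2O)CC1`, which carries a chloro group, gives 8710 nM. Compound 2 `COCc1cc(CN2CCC(C)CC2)c(O)c2ncccc12`, with methoxymethyl on that aromatic carbon instead, gives 13800 nM. Going by the values given here, these are the only two numbers available, and they lie within the scatter of each other, so compound 2 cannot be separated from compound 1.

Compound 3 `CC1CCN(Cc2cc(COC(C)C)c3cccnc3c2O)CC1` differs from compound 2 only at the end of that ether: isopropyl in place of methyl on an oxygen on a saturated carbon. This turns methoxymethyl to isopropoxymethyl. Among the compounds with values here, one measured step bears on the change, and only indirectly. It is a 1.6-fold higher number from compound 1 to compound 2 (0.20 log units; within the scatter), which concerns the same substituent but exchanges the whole group. Within the data shown here, no measured pair tests the group on the oxygen itself, so the data give no ground for expecting a move beyond the scatter in either direction. The estimated step is a 1.2-fold lower number from compound 2 to compound 3 (0.06 log units; within the scatter), which amounts to no expected change beyond the scatter. Compound 3 is therefore expected to read 12000 nM in this assay, with an estimated range of 5500 nM to 26000 nM.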

Compound 3, half-maximal inhibitory concentration: 7080 nM
For compound 3 the middle estimate is 1.7-fold (0.23 log units) above the measured one; the range from low to high includes it.
By their numbers in this assay, from the lowest: compounds 3, 1 and 2 (each within the scatter of the next).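

In this assay, isopropyl in place of methyl on an oxygen on a saturated carbon gives a 1.9-fold lower number from compound 2 to compound 3 (0.29 log units; within the scatter) and so provides the first measured test of the group on that oxygen, a test that stays within the scatter. Replacing chloro on the aromatic carbon with the whole isopropoxymethyl group gives a 1.2-fold lower number from compound 1 to compound 3 (0.09 log units; within the scatter) and also stays within the scatter, so chloro, methoxymethyl and isopropoxymethyl cannot be told apart at this position in compound 1, compound 2 and compound 3. No measurement at hand offers an explanation for this reading.

From the compounds shown here alone, whether a longer chain on the oxygen, or an amine or a carboxylic acid in place of the ether, would move the number beyond the scatter remains open. Going by these compounds alone, it is also open whether exchanging methyl for isopropyl on that oxygen would read the same way on a core other than the one shared by compound 2 and compound 3.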